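From pyrrolidin-1-yl to 4-methylpiperazin-1-yl on the thiocarbonyl carbon

The source may report more compounds than this note shows. Statements on the series, on what has been measured and on what is new or still open speak of the compounds shown alone.

Of the compounds shown here, two sharing one core have been measured so far in a functional assay on MDA-MB-231 cells (Homo sapiens) for inhibition, read by MTT assay, with stated times of 18 h and 4 h; a higher number here means a weaker inhibitor, a lower number a stronger inhibitor. Compound 1 `CCCCCCCCOP(=O)(O)OCCSC(=S)N1CCCC1` gives 69000 nM, and compound 2 `CCCCCCCCCCOP(=O)(O)OCCSC(=S)N1CCCC1` gives 67000 nM. Within the data shown here, the step between them is a 1.0-fold lower number from compound 1 to compound 2 (0.01 log units; within the scatter), so compound 2 stands level with the only other number available.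

Compound 3 `CCCCCCCCCCOP(=O)(O)OCCSC(=S)N1CCN(C)CC1` keeps the chain of compound 2 and alters one group, with 4-methylpiperazin-1-yl in place of pyrrolidin-1-yl on a thiocarbonyl carbon.

Among the measured compounds shown here, the one measured step, a 1.0-fold lower number from compound 1 to compound 2 (0.01 log units; within the scatter), lies on the saturated chain and does not touch the thiocarbonyl carbon, so it bears on this change only indirectly. For the measured compounds named here, no measured compound carries 4-methylpiperazin-1-yl, and the data hold no precedent for a change at this place. With no evidence for a shift in either direction, no step beyond the scatter is expected, though with little confidence. The expected step is a 1.1-fold lower number from compound 2 to compound 3 (0.05 log units; within the scatter). The estimate for compound 3 is 60000 nM, with an expected range from 22000 nM to 140000 nM.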

Compound 3, half-maximal inhibitory concentration: 29000 nM
For compound 3 the middle estimate is 2.1-fold (0.32 log units) above the measured one; the range from low to high includes it.
By their numbers in this assay, from the lowest: compound 3; then compounds 2 and 1 (each within the scatter of the next).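

In this assay, among these compounds, the group on the thiocarbonyl carbon is the first place in this set where a single change moves the number beyond the scatter (a 2.3-fold lower number from compound 2 to compound 3 (0.36 log units; beyond the scatter)), whereas the chain change stayed within it (a 1.0-fold lower number from compound 1 to compound 2 (0.01 log units; within the scatter)). The step is modest and rests on one pair of compounds, but it shows that this place responds to a change where the chain change gave no readable shift, and that the response to 4-methylpiperazin-1-yl in place of pyrrolidin-1-yl runs towards a stronger inhibitor. Nothing at hand accounts for this step, so its origin remains unexplained.

The compounds shown leave open whether the gain comes from the six-membered ring, the second ring nitrogen or its methyl group, a question that piperidin-1-yl, morpholin-4-yl or an unsubstituted piperazin-1-yl on the thiocarbonyl carbon would help to separate. They also leave open whether 4-methylpiperazin-1-yl gives a similar step on the shorter chain of compound 1 or on a chain longer than that of compound 2.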